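The source may report more compounds than this note shows. Statements on the series, on what has been measured and on what is new or still open speak of the compounds shown alone.

Compound 1 `O=c1c(O)c(-c2ccccc2)oc2cc(OCc3cccc(Cl)c3)cc(O)c12` in an ADME assay on Huh-5-2 cells (Homo sapiens) for cytotoxicity, read by WST assay, with a stated time of 3 days (a lower number here means that less compound is tolerated, a higher number that more compound is tolerated), gives a limit of the assay, > 100000 nM. Compound 2 `O=c1c(O)c(-c2ccccc2)oc2cc(OCc3cccc(Br)c3)cc(O)c12` likewise gives a limit in this assay, > 100000 nM. Compound 3 `O=c1c(O)c(-c2ccccc2)oc2cc(OCc3cccc([N+](=O)[O-])c3)cc(O)c12` gives 76000 nM in this assay.

Among the compounds with values here, compound 3 thus holds the only number in the set, the other two sitting at the limit of > 100000 nM in this assay, at which 2 of the 3 values shown sit. Compound 4 `O=c1c(O)c(-c2ccccc2)oc2cc(OCc3ccc([N+](=O)[O-])cc3)cc(O)c12` differs from compound 3 by 4-nitrophenyl in place of 3-nitrophenyl on a saturated chain carbon bound to an oxygen on an aromatic ring. Within the data shown here, the steps that bear on this are small: an at least 1.3-fold lower number from compound 1 to compound 3 (0.11 log units; that floor lies within the scatter) and an at least 1.3-fold lower number from compound 2 to compound 3 (0.11 log units; that floor lies within the scatter), while a step that the two limits leave unreadable from compound 1 to compound 2. None of these shows a change beyond the scatter, and the shift of the nitro group within the benzyl part is not expected to do more. The expected step is no change at the digits printed from compound 3 to compound 4 (within the scatter). The estimate for compound 4 is 76000 nM, between 35000 nM and 160000 nM.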

Compound 4, half-maximal cytotoxic concentration: 93000 nM
For compound 4 the middle estimate is 1.2-fold (0.09 log units) below the measured one, and the stated range covers the measured number.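

In this assay, 4-nitrophenyl in place of 3-nitrophenyl on this saturated chain carbon gives a 1.2-fold higher number from compound 3 to compound 4 (0.09 log units; within the scatter), so the two nitro isomers are not told apart here. Against the halogen compounds only floors can be read, an at least 1.0-fold lower number from compound 2 to compound 4 (0.03 log units; that floor lies within the scatter) and an at least 1.0-fold lower number from compound 1 to compound 4 (0.03 log units; that floor lies within the scatter), and neither separates the compounds. Compound 1 and compound 2 stay at a limit of the assay: the limit of > 100000 nM in this assay, at which 2 of the 4 values shown sit. As far as these compounds go, whether an amine or a carboxylic acid in place of the nitro group, or a longer chain in place of the benzyl part, would move the number beyond the scatter stays open.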